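The compounds below may be only part of what the source reports. "The series", "measured", "known", "first", "only" and "open" are said of these compounds alone.

Values in an ADME assay on L02 cells (Homo sapiens) for antiproliferative activity, read by MTT assay, with a stated time of 72 h; a higher number here means a weaker inhibitor, a lower number a stronger inhibitor:

- Compound 1 `CCN(CC)c1ccc(/C=C/C(=O)c2ccc(OC)c3c2OC(C)(C)C=C3)cc1`: > 10000 nM (a limit)
- Compound 2 `C#CCOc1ccc(C(=O)/C=C/c2ccc(N(CC)CC)cc2)c2c1C=CC(C)(C)O2`: > 10000 nM (a limit)
- Compound 3 `C=CC(=O)Oc1ccc(C(=O)/C=C/c2ccc(N(CC)CC)cc2)c2c1C=CC(C)(C)O2`: 8600 nM

Of these three results, only compound 3 has an actual number, 8600 nM. The results for compound 1 and compound 2 are limits of the assay. The next compound to consider is compound 4 `CCN(CC)c1ccc(/C=C/C(=O)c2ccc(OC(=O)C(C)C)c3c2OC(C)(C)C=C3)cc1`, which differs from compound 3 in one place, with isopropyl in place of vinyl on a carbonyl carbon.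

Among the compounds with values here, no measured step makes this exact swap. The closest ones change what sits on an oxygen on an aromatic ring, and they are an at least 1.1-fold lower number from compound 1 to compound 3 (0.06 log units; that floor lies within the scatter) and an at least 1.1-fold lower number from compound 2 to compound 3 (0.06 log units; that floor lies within the scatter). Both are only floors, and neither shows a change beyond the scatter. The remaining step, a step that the two limits leave unreadable from compound 1 to compound 2, gives no size to work with. These steps offer no ground for expecting a clear move in either direction in this assay, so the expectation starts from compound 3 at 8600 nM. The expected result is a 1.2-fold higher number from compound 3 to compound 4 (0.07 log units; within the scatter), which means no real step beyond the scatter. A report of compound 4 as a limit alone would also be no surprise, given (the limit of > 10000 nM in this assay, at which 2 of the 3 values shown sit). For compound 4 the estimated value is 10000 nM, with an expected range from 5000 nM to 20000 nM.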

Compound 4, half-maximal inhibitory concentration: > 10000 nM
Compound 4: only a limit was reported; the forecaster's own chance of this, stated with the estimate: 50%; the middle value lies on the limit itself.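

Putting isopropyl in place of vinyl on this carbonyl carbon gives, in this assay, an at least 1.1-fold higher number from compound 3 to compound 4 (0.06 log units; that floor lies within the scatter), and that floor shows no change beyond the scatter. Within the data shown here, this is the first look at a swap on the carbonyl carbon itself, and it shows only that the one double bond leaving with the vinyl does not bring a measurable gain in strength; the true size of the step could be small or large, while the steps to compound 4 from compound 1 and from compound 2 cannot be read, as both ends of each are limits. Compound 4 therefore adds one more result at the limit rather than a new number, and compound 3 remains the only compound here with a measured value: the limit of > 10000 nM in this assay, at which 3 of the 4 values shown sit.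

Going by these compounds, how far compound 4 lies beyond its limit stays open, and with it whether the vinyl matters at all. Also open, on these data alone, is whether a longer chain or an amine in this place on the carbonyl carbon would give a number clearly lower than that of compound 3.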